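The source may report more compounds than this note shows. Statements on the series, on what has been measured and on what is new or still open speak of the compounds shown alone.

Measured so far in an ADME assay on MT4 cells (Homo sapiens) for cytotoxicity, read by MTT assay; on this read-out higher numbers stand for lower toxicity in this test and lower numbers for higher toxicity in this test:
- compound 1, `O=C1c2ccccc2C(=O)N1CCOC(=S)N(C(=O)c1ccc(Br)cc1)c1ccc(Br)cc1`: 73000 nM
- compound 2, `O=C1c2ccccc2C(=O)N1CCOC(=S)N(C(=O)c1cccc(F)c1F)c1ccc(Cl)cc1`: 58000 nM
- compound 3, `Cc1ccc(N(C(=O)c2ccc(Cl)c(Cl)c2)C(=S)OCCN2C(=O)c3ccccc3C2=O)cc1`: 17000 nM

Compound 2 stands second highest of the three numbers. Its nearest neighbour is compound 1, whose value lies within the scatter of repeated measurement, so no order between compound 1 and compound 2 can be read from these two values. Compound 3 lies furthest from compound 2, with a lower number that is beyond the scatter; on this read-out that means compound 3 shows higher toxicity in this assay than compound 2.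

The next compound to be measured is compound 4, `O=C1c2ccccc2C(=O)N1CCOC(=S)N(C(=O)c1ccc2ccccc2c1)c1ccc(Cl)cc1`. It differs from compound 2 in one place:

naphthalen-2-yl in place of 2,3-difluorophenyl on a carbonyl carbon

Among the compounds with values here, no step between measured compounds covers this change, so nothing here shows how the naphthalen-2-yl group in place of the 2,3-difluorophenyl group on the carbonyl carbon moves the cytotoxicity number. In this assay the expected step from compound 2 to compound 4 is small, most likely within the scatter, if anything toward a lower number; the estimated step is a 1.5-fold lower number from compound 2 to compound 4 (0.16 log units; within the scatter).

For compound 4 the estimated value in this assay is 40000 nM, within a range from 15000 nM to 100000 nM.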

Compound 4, half-maximal cytotoxic concentration: 37000 nM
Compound 4: the middle estimate sits 1.1-fold (0.03 log units) above what was measured; the range from low to high includes it.
By their numbers in this assay, from the lowest: compound 3; then compounds 4, 2 and 1 (each within the scatter of the next).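

Within the data shown here, the step of a 1.6-fold lower number from compound 2 to compound 4 (0.20 log units; within the scatter) is the first reading in this assay of a change at a single place, on the carbonyl carbon whose other neighbour is the amide-type nitrogen. Here, a fused two-ring naphthalen-2-yl group replaces the single-ring 2,3-difluorophenyl group, with both fluorine atoms lost and the group growing from 8 to 10 heavy atoms, yet the two numbers cannot be told apart, so this one exchange gives no detectable shift in the read-out. No measurement available here speaks to why the number holds across this exchange.

As far as these compounds go, whether this position stays as unresponsive with a different kind of group, such as a basic amine, a carboxylic acid or a longer alkyl chain in place of the aryl ring, remains open, since a single pair of aryl groups cannot define a trend. The remaining pairs among the compounds differ in more than one place, so their steps cannot be read, and what lies behind the low number of compound 3 stays unassigned to any one part of its structure.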